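Series notes: phenyl replacing pyridin-3-yl on the core

The source may report more compounds than this note shows. Statements on the series, on what has been measured and on what is new or still open speak of the compounds shown alone.

Of the compounds shown here, three have been measured in a functional assay on KG-1 cells (Homo sapiens) for cytotoxicity, read by luminescence and CellTiter-Glo, with a stated time of 3 days; on this read-out lower numbers stand for stronger inhibition and higher numbers for weaker inhibition. Compound 1 `N#Cc1ccc(NC(=O)c2ccc(-c3cccnc3)cc2O)cc1` gives 7940 nM in this assay, the highest number of the three. Compound 3 `N#Cc1ccc(NC(=O)c2cccc(Br)c2O)cc1` gives 3260 nM in this assay, the nearest to compound 1, and the gap between the two lies beyond the scatter. Compound 2 `O=C(Nc1cc(C(F)(F)F)cc(C(F)(F)F)c1)c1cc(Cl)c(F)cc1O` gives 470 nM in this assay, the furthest from compound 1, again beyond the scatter. Within the data shown here, no pair among the measured compounds differs in only one place, so no single-change step is available as a guide.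

Compound 4 `N#Cc1ccc(NC(=O)c2ccc(-c3ccccc3)cc2O)cc1` is the next candidate. Its change from compound 1: phenyl in place of pyridin-3-yl on an aromatic carbon The hydroxy group and the remainder of the shared core are kept. Without a measured step of this kind, the step expected from this change is estimated at a 1.6-fold lower number from compound 1 to compound 4 (0.20 log units; within the scatter), that is, little movement beyond the scatter, with a slight lean toward a lower number. Compound 4 is estimated at 5000 nM in this assay, with a range from 1500 nM to 15000 nM.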

Compound 4, half-maximal inhibitory concentration: 410 nM
The estimate for compound 4 lay 12-fold (1.09 log units) above the measured number; measured number below the stated range.
By their numbers in this assay, from the lowest: compounds 4 and 2 (each within the scatter of the next); then compound 3; then compound 1.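

In this assay, phenyl in place of pyridin-3-yl gives a 19-fold lower number from compound 1 to compound 4 (1.29 log units; beyond the scatter), so this aromatic carbon, meta to a hydroxy group and para to a large group, responds strongly to a change within the ring it carries. The two rings have the same count of heavy atoms and both are six-membered and aromatic; the counted differences are the ring nitrogen and the one hydrogen-bond acceptor that leave with it. Nothing measured here accounts for the size of this step.

On these data alone, whether the ring nitrogen itself matters remains open, since a pyridin-4-yl or pyridin-2-yl group at this place would be needed to test its location. Also open, as far as these compounds go, is how a phenyl ring carrying an amine or a carboxylic acid would compare with the plain phenyl of compound 4.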